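Varying the Aryl Ether on a Thromboxane Synthase Inhibitor

The compounds below may be only part of what the source reports. "The series", "measured", "known", "first", "only" and "open" are said of these compounds alone.

Compound 1, `CC(C)(Oc1ccc(F)cc1)C1OCC(C/C=C\CCC(=O)O)C(c2cccnc2)O1`: 51 nM
Compound 2, `COc1ccccc1OC(C)(C)C1OCC(C/C=C\CCC(=O)O)C(c2cccnc2)O1`: 60 nM
Compound 3, `CC(C)(Oc1ccccc1O)C1OCC(C/C=C\CCC(=O)O)C(c2cccnc2)O1`: 32 nM

All three compounds share one core and were tested in an assay for inhibition of Thromboxane-A synthase (Homo sapiens), using microsomes; on this read-out lower numbers stand for stronger inhibition and higher numbers for weaker inhibition. They differ only in the aromatic group attached through an oxygen on a saturated carbon. Compound 3 sits at the low end of the three numbers, yet its gaps to the others, a 1.6-fold lower number from compound 1 to compound 3 (0.20 log units; within the scatter) and a 1.9-fold lower number from compound 2 to compound 3 (0.27 log units; within the scatter), are within the scatter, so the three cannot be told apart on these data.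

The next compound, compound 4, `COc1ccc(OC(C)(C)C2OCC(C/C=C\CCC(=O)O)C(c3cccnc3)O2)c([N+](=O)[O-])c1`, carries a larger group at the same place: 4-methoxy-2-nitrophenyl in place of 2-hydroxyphenyl on an oxygen on a saturated carbon.

Within the data shown here, every measured step so far changes exactly this aromatic group, and none of them moved the number beyond the scatter: a 1.2-fold higher number from compound 1 to compound 2 (0.07 log units; within the scatter), a 1.6-fold lower number from compound 1 to compound 3 (0.20 log units; within the scatter), a 1.9-fold lower number from compound 2 to compound 3 (0.27 log units; within the scatter). From the compounds shown here alone, nothing measured yet carries a nitro group, so its effect is unknown. Resting on the three steps that exist, the expected outcome is again no change beyond the scatter, a 1.6-fold higher number from compound 3 to compound 4 (0.19 log units; within the scatter). For compound 4 the estimated value in this assay is 50 nM, with a range from 20 nM to 150 nM.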

Compound 4, half-maximal inhibitory concentration: 37 nM
The estimate for compound 4 lay 1.4-fold (0.13 log units) above the measured number; the range from low to high includes it.
By their numbers in this assay, from the lowest: compounds 3, 4, 1 and 2 (each within the scatter of the next).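

Replacing 2-hydroxyphenyl with the larger 4-methoxy-2-nitrophenyl on the oxygen on a saturated carbon gives, in this assay, a 1.2-fold higher number from compound 3 to compound 4 (0.06 log units; within the scatter), and the comparisons with the other two aromatic groups give a 1.6-fold lower number from compound 2 to compound 4 (0.21 log units; within the scatter) and a 1.4-fold lower number from compound 1 to compound 4 (0.14 log units; within the scatter). This position therefore accepts a group with a nitro substituent, more heavy atoms and no hydrogen-bond donor, and all four compounds remain within the scatter of their neighbours in the ranking, so the hydroxyl of compound 3 is not required for a number in this range. No independent measurement here accounts for this flat response.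

From the compounds shown here alone, it remains open whether the same holds for an aromatic ring bearing an amine or a carboxylic acid, or for a cyclohexyl group in place of the aromatic ring. These four compounds also share the same core and the same acid-bearing side chain, so they cannot show how changes to either of those parts, such as a shorter chain or an amide in place of the carboxylic acid, would affect the number.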